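The source may report more compounds than this note shows. Statements on the series, on what has been measured and on what is new or still open speak of the compounds shown alone.

Working notes on the series. In an ADME assay on microsomes from liver (Homo sapiens) for metabolic stability, read by LC-MS, using NADPH, with a stated time of 120 min, tested at 1 uM (a lower number here means slower removal, a higher number faster removal of the compound), compound 1 (`CCC(O)CNC(=O)C[C@H](CCC1CCCCC1)NC(=O)c1cc(-c2c(OC)cccc2OC)n(CC(C)C)n1`) gives 389 mL/min/kg and compound 2 (`CC[C@@H](O)CNC(=O)C[C@H](CCC1CCCCC1)NC(=O)c1cc(-c2c(OC)cccc2OC)n(CC(C)C)n1`) gives 402 mL/min/kg in the same test. Compound 3 (`COC(=O)CN(C)C(=O)[C@H](CCc1ccccc1)NC(=O)c1cc(-c2c(OC)cccc2OC)n(CC(C)C)n1`) gives 153 mL/min/kg in this assay as the lowest of the three numbers, beyond the scatter from both of the others.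

The next compound is compound 4 (`CCC(=O)CNC(=O)[C@H](CCc1ccccc1)NC(=O)c1cc(-c2c(OC)cccc2OC)n(CC(C)C)n1`), which has not yet been measured. Its difference from compound 3 is as follows ((propanoylmethyl)amino in place of ((methoxycarbonyl)methyl)(methyl)amino on a carbonyl carbon). In words, (propanoylmethyl)amino stands in place of ((methoxycarbonyl)methyl)(methyl)amino on a carbonyl carbon.

Among the measured compounds shown here, the only measured step (a 1.0-fold higher number from compound 1 to compound 2 (0.01 log units; within the scatter)) lies within the scatter and concerns only how one stereocentre is drawn (the fact that one of compounds 1 and 2 is drawn with a defined configuration and the other without, at the place where they differ). For the measured compounds named here, it does not involve the group exchanged here, so no measured step gives the size or direction of this change. The estimate therefore stays anchored on the only close reference, compound 3 (153 mL/min/kg), and its range is kept wide.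

The expected step in this assay is none beyond the scatter (a 1.1-fold higher number from compound 3 to compound 4 (0.03 log units; within the scatter)). For compound 4 the estimated clearance is 165 mL/min/kg with an expected range from 75 mL/min/kg to 360 mL/min/kg in this test.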

Compound 4, clearance: 36 mL/min/kg
Compound 4: the middle estimate sits 4.6-fold (0.66 log units) above what was measured; measured number outside the range, below it.
By their numbers in this assay, from the lowest: compound 4; then compound 3; then compounds 1 and 2 (each within the scatter of the next).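

In this assay the place on a carbonyl carbon proves sensitive to the group it carries: (propanoylmethyl)amino in place of ((methoxycarbonyl)methyl)(methyl)amino gives a 4.3-fold lower number from compound 3 to compound 4 (0.63 log units; beyond the scatter), the only step shown beyond the scatter between compounds that differ in one place. The exchange changes more than one feature at once, since the nitrogen methyl gives way to the amide hydrogen and a propanoyl carbonyl stands where the methoxycarbonyl stood, so the step cannot be assigned to either feature alone. Nothing recorded for the series bears on why this exchange lowers the number.

From the compounds shown here alone, it stays open whether (methoxycarbonylmethyl)amino, which keeps the methoxycarbonyl but carries the amide hydrogen, would sit nearer compound 3 or compound 4, and whether a butanoylmethyl chain or a carboxymethyl group on the same carbonyl carbon would hold the lower number. Compounds 1 and 2 differ from compound 4 in more than one place, so the compounds shown also do not say whether this exchange would give a step of similar size on the cyclohexyl-bearing chain.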